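The source may report more compounds than this note shows. Statements on the series, on what has been measured and on what is new or still open speak of the compounds shown alone.

Working notes on the series. Compound 1 `O=C(NCc1ccccc1)C1CCN(Cc2ccccc2)CC1` and compound 2 `O=C(Nc1ccccc1)C1CCN(Cc2ccccc2)CC1` share one core and differ only at the amide nitrogen. In an assay on membranes from liver for displacement of a labelled ligand from Sigma non-opioid intracellular receptor 1 (Rattus norvegicus), read by scintillation counting (on this read-out lower numbers stand for stronger inhibition and higher numbers for weaker inhibition), compound 1 gives 22.5 nM, and in this assay compound 2 gives 48.1 nM; the step of a 2.1-fold higher number from compound 1 to compound 2 (0.33 log units; beyond the scatter) is the only measured one, and it leaves compound 2 with the highest of the two numbers. Compound 3 `Cc1ccc(CN2CCC(C(=O)Nc3ccccc3)CC2)cc1` departs from compound 2 by methyl in place of hydrogen on an aromatic carbon, placed para to a large group on the ring carried by the basic nitrogen. Going by the values given here, no measured step touches that ring: the single step available, from benzyl to phenyl on the amide nitrogen, lies on the other side of the core and gives no guide to a methyl on the aromatic ring. With nothing to lean on, no step beyond the scatter is expected, so a 1.0-fold lower number from compound 2 to compound 3 (0.00 log units; within the scatter) is set near zero. Compound 3 is therefore estimated at 48 nM, with a range from 20 nM to 115 nM.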

Compound 3, inhibition constant: 105 nM
Estimate against measurement, compound 3: 2.2-fold (0.34 log units) below; measured number inside the range.
By their numbers in this assay, from the lowest: compound 1; then compound 2; then compound 3.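

The change from phenyl to 4-methylphenyl gives a 2.2-fold higher number from compound 2 to compound 3 (0.34 log units; beyond the scatter) in this assay, so the aromatic ring that takes the methyl, which the earlier step at the amide nitrogen did not touch, is not indifferent to this one added carbon. At this place, para to a large group, the methyl moves the number upward, as phenyl in place of benzyl on the amide nitrogen did with a 2.1-fold higher number from compound 1 to compound 2 (0.33 log units; beyond the scatter), and both steps lie beyond the scatter. Nothing given here bears on why the number rises with this methyl.

Open, as far as these compounds go, is whether methoxy, chlorine or an amine at this same place would raise the number as methyl does. Also open, from the compounds shown here alone, is whether the same methyl on the benzyl amide of compound 1 would give a step of this direction and size.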